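Swapping an amide for a free acid on a shared core

The source may hold more compounds than are shown below. What is called first, only, known or untested is meant among the compounds shown, and "the series" means these compounds.

Two measured relatives set the scene. Compound 1 `CCOC(=O)/C=C/c1ccncc1-c1ccc2[nH]ccc2c1` gives 4830 nM in a functional assay on HCT-116 cells (Homo sapiens) for inhibition, read by MTT assay, with a stated time of 72 h (a lower number here means a stronger inhibitor of growth, a higher number a weaker inhibitor of growth), and compound 2 `CNC(=O)/C=C/c1ccncc1-c1ccc2c(cnn2C)c1` gives 3480 nM in this assay. Compound 3 `Cn1ncc2cc(-c3cnccc3/C=C/C(=O)N3CCOCC3)ccc21` gives "not determined" (no result reported) in this assay, so it has no number there and its standing cannot be placed among them. Compound 4 `Cn1ncc2cc(-c3cnccc3/C=C/C(=O)O)ccc21` differs from compound 3 by hydroxy in place of morpholin-4-yl on a carbonyl carbon. Among the measured compounds shown here, no measured pair shows this kind of change, and the change has a larger group leaving than entering, so a sizeable step toward weaker growth inhibition in this assay is expected rather than none beyond the scatter. Compound 4 is expected to give about 15000 nM, likely between 4000 nM and 50000 nM, if the measurement reports a number at all.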

Compound 4, concentration for 50% growth inhibition: > 30000 nM
Compound 4: a limit, no number (the forecaster's own chance of this, stated with the estimate: 25%); at least 2.0-fold (0.30 log units) between middle value and limit.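

In this assay compound 4 gives a limit, not a number: the limit of > 30000 nM in this assay, at which 1 of the 4 values shown sits. Hydroxy in place of methylamino brings an at least 8.6-fold higher number from compound 2 to compound 4 (0.93 log units; beyond the scatter) on a carbonyl carbon whose other neighbour is the double-bonded chain carbon. Among the compounds shown here, this is the first sign that growth inhibition depends on what this carbonyl carbon carries, which compound 2 alone could not show.

Compound 3 has no number, so the step from its morpholin-4-yl amide to compound 4 cannot be read. As far as these compounds go, how an unsubstituted amide or a dimethylamino amide would behave at this place stays open.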